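The compounds below may be only part of what the source reports. "The series", "measured", "known", "first", "only" and "open" are said of these compounds alone.

Measured so far in an assay on membranes from brain (Cavia porcellus) for binding affinity to Sigma non-opioid intracellular receptor 1 (Homo sapiens); a lower number here means a stronger inhibitor, a higher number a weaker inhibitor:
compound 1, `Cc1ccccc1/N=C(/N)Nc1ccccc1I`: 21 nM
compound 2, `Cc1ccccc1/N=C(/N)Nc1ccccc1N`: 463 nM

Compound 2 holds the higher of the two numbers in this assay. Within the data shown here, its only neighbour is compound 1, and the step between them, a 22-fold higher number from compound 1 to compound 2 (1.34 log units; beyond the scatter), is a large one, well beyond the scatter. Compound 3, `Cc1ccccc1/N=C(/N)Nc1ccccc1[N+](=O)[O-]`, has not yet been measured in this assay. It differs from compound 2 in one place: nitro in place of amino on an aromatic carbon.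

Among the measured compounds shown here, no measured step covers an exchange of amino for nitro. For the measured compounds named here, the one step that bears on this place, a 22-fold higher number from compound 1 to compound 2 (1.34 log units; beyond the scatter), shows only that replacing the group on this aromatic carbon moves the number strongly, and that the amino group gives the weaker of the two measured numbers. Since compound 2 already stands at the high end, a further change at the same place is expected to move the number down rather than up, though by how much is uncertain. The expected step is a 4.2-fold lower number from compound 2 to compound 3 (0.62 log units; beyond the scatter). Compound 3 is therefore expected to give about 110 nM in this assay, within a range from 25 nM to 450 nM.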

Compound 3, half-maximal inhibitory concentration: 113 nM
For compound 3 the middle estimate is 1.0-fold (0.01 log units) below the measured one; measured number inside the range.
By their numbers in this assay, from the lowest: compound 1; then compound 3; then compound 2.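

In this assay, the nitro group adds a third point at this position on an aromatic carbon, ortho to a large group, where there had been only a contrast between iodo and amino. The step of a 4.1-fold lower number from compound 2 to compound 3 (0.61 log units; beyond the scatter) and the step of a 5.4-fold higher number from compound 1 to compound 3 (0.73 log units; beyond the scatter) are both beyond the scatter, so the three groups give three separate numbers, with nitro between amino and iodo. The position therefore does not simply divide groups into those that give a low number and those that give a high one, although nothing here accounts for this order of iodo, nitro and amino.

The compounds shown leave open where other groups on this aromatic carbon would fall in that order, such as a chlorine atom, a methoxy group or a carboxylic acid. They also leave open whether the same order would hold if the methyl group elsewhere on the shared core gave way to an ethyl chain or a bromine atom.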